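Replacing 2,4-difluorophenyl with 4-(trifluoromethyl)phenyl

A few compounds are considered here, and "the series" means these few. Any claim that something is new, unique, unknown or untested is made for them only; others in the source may bear on it.

In a functional assay on RT-112 cells (Homo sapiens) for antiproliferative activity, read by MTT assay, with a stated time of 72 h (on this read-out lower numbers stand for stronger inhibition of growth and higher numbers for weaker inhibition of growth), compound 1 `COc1cc(Nc2ncnc3c(NC(=O)Nc4ccc(Cl)cc4)cccc23)cc(OC)c1` gives 2490 nM and compound 2 `COc1cc(Nc2ncnc3c(NC(=O)Nc4ccc(F)cc4F)cccc23)cc(OC)c1` gives 2460 nM, so compound 2 stands level with compound 1 within the scatter. Compound 3 `COc1cc(Nc2ncnc3c(NC(=O)Nc4ccc(C(F)(F)F)cc4)cccc23)cc(OC)c1` changes the group on the amide-type nitrogen: 4-(trifluoromethyl)phenyl in place of 2,4-difluorophenyl on an amide-type nitrogen. For the measured compounds named here, the only measured step at this place, 2,4-difluorophenyl in place of 4-chlorophenyl, is a 1.0-fold lower number from compound 1 to compound 2 (0.01 log units; within the scatter), which lies within the scatter. No change beyond the scatter is therefore expected in this assay, and the estimated step is a 1.1-fold lower number from compound 2 to compound 3 (0.03 log units; within the scatter). Compound 3 is expected at 2300 nM, within an estimated range of 900 nM to 5500 nM.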

Compound 3, concentration for 50% growth inhibition: 3920 nM
Estimate against measurement, compound 3: 1.7-fold (0.23 log units) below; the range from low to high includes it.
By their numbers in this assay, from the lowest: compounds 2, 1 and 3 (each within the scatter of the next).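

In this assay, this place on the amide-type nitrogen now carries a third substituted phenyl group, and the exchange for 4-(trifluoromethyl)phenyl gives no change beyond the scatter (a 1.6-fold higher number from compound 2 to compound 3 (0.20 log units; within the scatter)). Trifluoromethyl in place of chloro on an aromatic carbon likewise stays within the scatter (a 1.6-fold higher number from compound 1 to compound 3 (0.20 log units; within the scatter)), so the three phenyl groups shown cannot be told apart in this assay. No evidence is available that bears on this result. Still open, from the compounds shown here alone, is whether a phenyl group carrying an amine or a carboxylic acid, or a longer chain in place of the phenyl ring, would move the number beyond the scatter.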